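The source may hold more compounds than are shown below. What is called first, only, known or untested is meant among the compounds shown, and "the series" means these compounds.

Compound 1 `Cc1ccc(OC(=O)N(Nc2ccccc2)S(=O)(=O)c2ccccc2)cc1`: in a functional assay on RAW264.7 cells (Mus musculus), read by immunoassay, with a stated time of 24 h (a higher number here means a weaker inhibitor, a lower number a stronger inhibitor), compound 1 gives 1020 nM.
Compound 2 `COc1ccc(OC(=O)N(Nc2ccccc2)S(=O)(=O)c2ccccc2)cc1`: in this assay compound 2 gives 584 nM.

Among the compounds with values here, compound 2 is one of only two measured compounds, and its sole neighbour, compound 1, lies within the scatter of it, as the step of a 1.7-fold lower number from compound 1 to compound 2 (0.24 log units; within the scatter) shows. Compound 3 `COc1ccc(OC(=O)N(Nc2ccccc2)S(=O)(=O)c2ccc(OC)cc2)cc1` has not been measured; it differs from compound 2 by methoxy in place of hydrogen on an aromatic carbon. Within the data shown here, the one measured step, a 1.7-fold lower number from compound 1 to compound 2 (0.24 log units; within the scatter), exchanges methyl for methoxy on another ring and stays within the scatter; no step puts methoxy where hydrogen was. A step within the scatter, in no clear direction, is therefore expected: a 1.1-fold lower number from compound 2 to compound 3 (0.03 log units; within the scatter). Compound 3 is estimated at 550 nM, between 200 nM and 1500 nM.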

Compound 3, half-maximal inhibitory concentration: 490 nM
Compound 3: middle estimate off by 1.1-fold (0.05 log units), on the high side; low and high end bracket the measured number.
By their numbers in this assay, from the lowest: compounds 3, 2 and 1 (each within the scatter of the next, the first and the last beyond it).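

In this assay the change from phenyl to 4-methoxyphenyl gives a 1.2-fold lower number from compound 2 to compound 3 (0.08 log units; within the scatter), so putting methoxy where hydrogen stood, para to a large group, leaves the number within the scatter. Within the data shown here, the earlier compounds held no step that replaced a hydrogen on this ring, so this is the first reading of that change. No measurement at hand says why the number stays within the scatter. As far as these compounds go, whether an amine, a carboxylic acid or a longer chain at this place would give a step beyond the scatter remains open.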